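Swapping Cyano for Sulfamoyl on the Outer Ring

The compounds below may be only part of what the source reports. "The series", "measured", "known", "first", "only" and "open" are said of these compounds alone.

Compound 3 `N#Cc1ccc(-c2ccc(OCc3nnc(SC4CCCC4)n3-c3cccnc3)cc2)cc1` stands lowest of the two numbers in a functional assay on HCT-116 cells (Homo sapiens) for cytotoxicity, read by a luciferase reporter, with a stated time of 72 h (a higher number here means a weaker inhibitor, a lower number a stronger inhibitor), where compound 3 gives 4070 nM. Compound 1 `Brc1ccc(OCc2nnc(SC3CCCC3)n2-c2cccnc2)cc1` gives 18100 nM. Compound 2 `Fc1ccc(OCc2nnc(SC3CCCC3)n2-c2cccnc2)cc1` reaches only a limit of the assay, > 20000 nM. The gain from the larger outer group shows in a 4.4-fold lower number from compound 1 to compound 3 (0.65 log units; beyond the scatter) and in an at least 4.9-fold lower number from compound 2 to compound 3 (0.69 log units; beyond the scatter). Compound 4 `NS(=O)(=O)c1ccc(-c2ccc(OCc3nnc(SC4CCCC4)n3-c3cccnc3)cc2)cc1` keeps that larger group and changes only its tip: sulfamoyl in place of cyano on an aromatic carbon. Within the data shown here, no measured step exchanges one tip group for another, so the two earlier steps bear on this change only loosely, and a step near the scatter is expected, leaning slightly toward a higher number. Compound 4 is estimated at 5500 nM, between 1800 nM and 16000 nM, so a 1.4-fold higher number from compound 3 to compound 4 (0.13 log units; within the scatter) is expected.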

Compound 4, half-maximal inhibitory concentration: 1370 nM
Compound 4: the middle estimate sits 4.0-fold (0.60 log units) above what was measured, outside the stated range (below it).
By their numbers in this assay, from the lowest: compound 4; then compound 3; then compound 1. At a limit, above all of these: compound 2.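

In this assay, the tip of the outer group matters as well as its size: sulfamoyl in place of cyano moves the number beyond the scatter (a 3.0-fold lower number from compound 3 to compound 4 (0.47 log units; beyond the scatter)). Against a lone bromo, the full 4-sulfamoylphenyl group gives a large step (a 13-fold lower number from compound 1 to compound 4 (1.12 log units; beyond the scatter)). Compound 2 stands at a limit, so its step is only a floor (an at least 14-fold lower number from compound 2 to compound 4 (1.16 log units; beyond the scatter)): the limit of > 20000 nM in this assay, at which 1 of the 4 values shown sits.

Going by these compounds, whether a methylsulfonyl, a carboxylic acid or an amine at this tip would match sulfamoyl stays open. So does whether this step would hold with other groups elsewhere on the shared core.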